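Replacing Chloro with Methoxycarbonyl When Only Limits Are Known

A few compounds are considered here, and "the series" means these few. Any claim that something is new, unique, unknown or untested is made for them only; others in the source may bear on it.

In an ADME assay on HeLa cells (Homo sapiens) for cytotoxicity, read by resazurin assay, with a stated time of 65 h (a higher number here means that more compound is needed for the effect, a lower number that less compound is needed), compound 1 (`O=C(Nc1ccccc1)c1ccc([N+](=O)[O-])o1`) gives > 20000 nM, which is a limit, not a number. Compound 2 (`O=C(Nc1ccc(C(F)(F)F)cc1)c1ccc([N+](=O)[O-])o1`) gives > 20000 nM, also a limit. On these data alone, compound 3 (`O=C(Nc1ccc(Cl)cc1)c1ccc([N+](=O)[O-])o1`) gives > 20000 nM, again a limit, so its true position is unknown. Compound 4 (`COC(=O)c1ccc(NC(=O)c2ccc([N+](=O)[O-])o2)cc1`) carries methoxycarbonyl in place of chloro on an aromatic carbon, para to a large group (methoxycarbonyl in place of chloro on an aromatic carbon). The nearest evidence is a step that the two limits leave unreadable from compound 1 to compound 3 and a step that the two limits leave unreadable from compound 2 to compound 3, and neither offers a size to carry over. All three compounds share one ceiling: the limit of > 20000 nM in this assay, at which 3 of the 3 values shown sit. No step beyond the usual scatter is therefore expected, and the expected change is a step that the limit leaves unreadable from compound 3 to compound 4. For compound 4 the estimated value is 25000 nM, with an expected range of 10000 nM to 60000 nM.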

Compound 4, half-maximal effective concentration: > 20000 nM
Compound 4 ended at the assay's limit (the forecaster's own chance of this, stated with the estimate: 75%); the middle value does not contradict the limit.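

Within the data shown here, no step from compound 1, compound 2 or compound 3 to compound 4 can be read, because all four compounds share one limit: the limit of > 20000 nM in this assay, at which 4 of the 4 values shown sit.

The compounds shown leave open where each true value lies, and whether swapping these groups changes it at all.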